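This account rests on a few compounds, and the source may have more. Where it says the series, first, only, none or still open, it means among the compounds named here.

In an assay on isolated protein for binding affinity to Oxytocin receptor (Homo sapiens) (a lower number here means a stronger inhibitor, a higher number a weaker inhibitor), compound 1 `CC(C)C[C@@H]1C(=O)N[C@H](C2Cc3ccccc3C2)C(=O)N1[C@@H](C(=O)NC(C)C)c1ccco1` gives 6.31 nM. Compound 2 `Cc1cc([C@H](C(=O)NC(C)C)N2C(=O)[C@@H](C3Cc4ccccc4C3)NC(=O)[C@H]2CC(C)C)oc1C` gives 1.26 nM in this assay, and compound 3 `CC(C)C[C@@H]1C(=O)N[C@H](C2Cc3ccccc3C2)C(=O)N1[C@@H](C(=O)NC(C)C)c1ccc(Br)s1` gives 2 nM in this assay. Of the three numbers, compound 3 stands second highest: its nearest neighbour is compound 2, separated by a step within the scatter, and its furthest is compound 1, separated by a step beyond it. Both measured steps that end at compound 3 concern the same position, the saturated chain carbon bound to the ring amide nitrogen and a carbonyl carbon: the step of a 3.2-fold lower number from compound 1 to compound 3 (0.50 log units; beyond the scatter) is modest but beyond the scatter, while the step of a 1.6-fold higher number from compound 2 to compound 3 (0.20 log units; within the scatter) lies within it. Compound 4 `CC(C)C[C@@H]1C(=O)N[C@H](C2Cc3ccccc3C2)C(=O)N1[C@@H](C(=O)NC(C)C)c1cc(Br)cs1` differs from compound 3 only in 4-bromothiophen-2-yl in place of 5-bromothiophen-2-yl on a saturated chain carbon bound to an amide-type nitrogen in a ring and a carbonyl carbon. Going by the values given here, both of those steps describe the arrival of the group that now leaves; no measured pair shows the group that enters, so the change from compound 3 to compound 4 has no direct precedent among the three compounds. Compound 4 is therefore expected to remain close to compound 3 in this assay, with an estimated step of a 1.5-fold higher number from compound 3 to compound 4 (0.18 log units; within the scatter) that would not clearly exceed the scatter. The estimate for compound 4 in this assay is 3 nM, within a range from 1 nM to 10 nM.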

Compound 4, inhibition constant: 1 nM
Compound 4: the middle estimate sits 3.0-fold (0.48 log units) above what was measured; the range from low to high includes it.
By their numbers in this assay, from the lowest: compounds 4, 2 and 3 (each within the scatter of the next); then compound 1.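

In this assay, going by these compounds alone, compounds 3 and 4 form the first pair at this position with the same atoms joined differently, and 4-bromothiophen-2-yl in place of 5-bromothiophen-2-yl gives a 2.0-fold lower number from compound 3 to compound 4 (0.30 log units; within the scatter), so on the saturated chain carbon the place of the bromine on the thiophene does not separate the two compounds beyond the scatter. The new group also stays level with 4,5-dimethylfuran-2-yl, with a 1.3-fold lower number from compound 2 to compound 4 (0.10 log units; within the scatter), yet it stands clearly apart from furan-2-yl, with a 6.3-fold lower number from compound 1 to compound 4 (0.80 log units; beyond the scatter), so all three substituted rings shown now lie beyond the scatter from the unsubstituted furan of compound 1, and no compound here goes against that. No independent measurement is available that bears on this result.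

As far as these compounds go, how a plain thiophen-2-yl would read at this place remains open, so the part played by the bromine cannot be separated from that of the sulfur-containing ring. Equally open, from the compounds shown here alone, is whether a ring carrying a chlorine, a methoxy group or an amine in place of the bromine would stay with these three compounds or fall back towards compound 1.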